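Chain shortening from compound 3 to compound 4

The compounds below may be only part of what the source reports. "The series", "measured", "known", "first", "only" and "open" are said of these compounds alone.

In a functional assay on MCF7 cells (Homo sapiens) for inhibition, read by MTT assay, with stated times of 18 h and 4 h (on this read-out lower numbers stand for stronger inhibition and higher numbers for weaker inhibition), compound 3 `CCCCCCCCCCOP(=O)(O)OCCSC(=S)N1CCN(C)CC1` gives 99600 nM, and compound 1 `CCCCCCCCCCOP(=O)(O)OCCSC(=S)N1CCCC1` gives 70000 nM. The change on the thiocarbonyl carbon is a 1.4-fold higher number from compound 1 to compound 3 (0.15 log units; within the scatter). Compound 2 `CCCCCCCCCCCCCCCCOP(=O)(O)OCCSC(=S)N1CCN(C)CC1` reads > 100000 nM, which is a limit of the assay. Compound 4 `CCCOP(=O)(O)OCCSC(=S)N1CCN(C)CC1` has hydrogen in place of heptyl on a saturated chain carbon, three bonds along the chain from an oxygen on an unsaturated carbon. For the measured compounds named here, the only measured chain change is a number no higher from compound 2 to compound 3 (the limit leaves the size open), so its size remains open and it gives no firm guide. No shift beyond the scatter is therefore expected in this assay, and a reading at the limit is possible. The expected step is a 1.0-fold higher number from compound 3 to compound 4 (0.00 log units; within the scatter). Compound 4 is estimated at 100000 nM, with an expected range of 50000 nM to 200000 nM.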

Compound 4, half-maximal inhibitory concentration: 59000 nM
The estimate for compound 4 lay 1.7-fold (0.23 log units) above the measured number, within the range that was stated.
By their numbers in this assay, from the lowest: compounds 4, 1 and 3 (each within the scatter of the next). At a limit, above all of these: compound 2.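

In this assay, for the compounds shown here, the first readable chain change at this position is a 1.7-fold lower number from compound 3 to compound 4 (0.23 log units; within the scatter). Loss of heptyl here therefore leaves the number inside the scatter, so across this shortening chain length shows no effect on the read-out. Compound 2 reads > 100000 nM, which is a limit: the limit of > 100000 nM in this assay, at which 1 of the 4 values shown sits.

Still open, as far as these compounds go, is whether an amine or a carboxylic acid on this chain would move the number beyond the scatter. Also open, from the compounds shown here alone, is whether the same shortening behaves alike with pyrrolidin-1-yl on the thiocarbonyl carbon.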